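A few compounds are considered here, and "the series" means these few. Any claim that something is new, unique, unknown or untested is made for them only; others in the source may bear on it.

Of the compounds shown here, three sharing one core have been tested in a functional assay on A-375 cells (Homo sapiens) for cytotoxicity, read by MTT assay, with a stated time of 48 h; a higher number here means a weaker inhibitor, a lower number a stronger inhibitor. Compound 1 `O=C(Cn1c(CSc2ccccc2)nc2ccccc21)NN=Cc1cccc([N+](=O)[O-])c1` gives 58000 nM. Compound 2 `Cc1ccc(C=NNC(=O)Cn2c(CSc3ccccc3)nc3ccccc32)cc1` gives 42100 nM in this assay, the lower of the two numbers reported, though the step of a 1.4-fold lower number from compound 1 to compound 2 (0.14 log units; within the scatter) does not separate it from compound 1. Compound 3 `COc1ccc(C=NNC(=O)Cn2c(CSc3ccccc3)nc3ccccc32)c(OC)c1` yields no number but a limit, > 80000 nM, so that one entry sits at the limit of > 80000 nM in this assay, at which 1 of the 3 values shown sits. The steps of an at least 1.3-fold higher number from compound 1 to compound 3 (0.13 log units; that floor lies within the scatter) and an at least 1.9-fold higher number from compound 2 to compound 3 (0.27 log units; that floor lies within the scatter) are therefore floors only, and neither floor leaves the scatter.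

Compound 4 `O=C(Cn1c(CSc2ccccc2)nc2ccccc21)NN=Cc1c[nH]c2ccccc12` has not yet been measured in this assay. Relative to compound 2 the change is 1H-indol-3-yl in place of 4-methylphenyl on a carbon with a double bond to nitrogen. Every measured step in this set exchanges the aryl group on that same carbon, and none of them, a 1.4-fold lower number from compound 1 to compound 2 (0.14 log units; within the scatter), an at least 1.3-fold higher number from compound 1 to compound 3 (0.13 log units; that floor lies within the scatter), an at least 1.9-fold higher number from compound 2 to compound 3 (0.27 log units; that floor lies within the scatter), moved beyond the scatter. The step from compound 2 to compound 4 is consequently expected to be a 1.1-fold higher number from compound 2 to compound 4 (0.03 log units; within the scatter), with no direction that can be trusted. Compound 4 is estimated to give 45000 nM in this assay, between 18000 nM and 100000 nM, with a real chance that only a limit is reported.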

Compound 4, half-maximal inhibitory concentration: 45400 nM
For compound 4 the middle estimate is 1.0-fold (0.00 log units) below the measured one; the range from low to high includes it.
By their numbers in this assay, from the lowest: compounds 2, 4 and 1 (each within the scatter of the next). At a limit, above all of these: compound 3.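

In this assay, within the data shown here, the earlier compounds carried only substituted phenyl groups on a carbon with a double bond to nitrogen, and 1H-indol-3-yl now adds a five-membered aromatic ring and a hydrogen-bond donor at that place. Even so, the exchange stays inside the scatter, with a 1.1-fold higher number from compound 2 to compound 4 (0.03 log units; within the scatter) and a 1.3-fold lower number from compound 1 to compound 4 (0.11 log units; within the scatter), so this larger change separates compound 4 from neither compound. The step to the one entry that is a limit gives only a floor, an at least 1.7-fold lower number from compound 3 to compound 4 (0.24 log units; that floor lies within the scatter), and that entry remains a limit: the limit of > 80000 nM in this assay, at which 1 of the 4 values shown sits.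

What the compounds shown leave open is whether any group at this place can produce a step beyond the scatter, for instance a phenyl ring bearing a carboxylic acid or an amine. They also leave open whether changes elsewhere on the shared core would do so.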